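The compounds below may be only part of what the source reports. "The series", "measured", "known", "first", "only" and "open" are said of these compounds alone.

Series of three measured compounds and one still pending. Compound 1 `Cc1ccc2nc(Nc3nc(Nc4ccc(S(N)(=O)=O)cc4)ncc3C)sc2c1` carries a sulfonamide and a methyl on the fused ring; in a functional assay on HCT-116 cells (Homo sapiens) for antiproliferative activity, read by MTT assay, with a stated time of 48 h (a higher number here means a weaker inhibitor, a lower number a stronger inhibitor), compound 1 gives 3870 nM. Compound 3 `Cc1cnc(Nc2ccc(S(N)(=O)=O)cc2)nc1Nc1nc2ccccc2s1` lacks that methyl; in this assay compound 3 gives 1660 nM. Methyl in place of hydrogen on an aromatic carbon gave a 2.3-fold higher number from compound 3 to compound 1 (0.37 log units; beyond the scatter); the change counted there is methyl in place of hydrogen on an aromatic carbon. Compound 2 `CS(=O)(=O)c1ccc(Nc2nccc(Nc3nc4ccc(F)cc4s3)n2)cc1` carries a methylsulfonyl and a fluorine; in this assay compound 2 gives 860 nM. How the cores of compound 2 and compound 3 differ is not broken down here; their two values sit close to each other.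

Compound 4 `Cc1cnc(Nc2ccc(S(C)(=O)=O)cc2)nc1Nc1nc2ccc(F)cc2s1` is compound 2 with methyl in place of hydrogen on an aromatic carbon. This is the same kind of change as the earlier methyl step, but not the same: earlier the methyl entered on a six-membered aromatic ring of carbon only, part of a fused or bridged system of two rings, meta to a fused ring and para to a fused ring; here it enters on a six-membered aromatic ring with 2 nitrogen, ortho to a large group, two atoms from the ring nitrogen, para to a large group. Going by the values given here, only one methyl step is known, and at another place. The expected step is a 1.3-fold higher number from compound 2 to compound 4 (0.11 log units; within the scatter), a modest move. It rests on compound 1 having given 3870 nM after its methyl came in. Compound 4 is estimated at 1100 nM, with a range from 450 nM to 2700 nM.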

Compound 4, half-maximal inhibitory concentration: 24000 nM
Estimate against measurement, compound 4: 22-fold (1.34 log units) below, outside the stated range (above it).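

In this assay, methyl in place of hydrogen on an aromatic carbon gave a 28-fold higher number from compound 2 to compound 4 (1.45 log units; beyond the scatter), so this change does not carry over from one core to another with a single size in this series, and the two known methyl steps differ: the same change on two cores in this assay, a 2.3-fold higher number (0.37 log units; beyond the scatter) from compound 3 to compound 1 and a 28-fold higher number (1.45 log units; beyond the scatter) from compound 2 to compound 4, 12-fold (1.08 log units) apart, beyond the scatter of two such steps

Both steps run in the same direction, towards a higher number, so neither pair shows any gain from the added methyl. The comparison does not show whether the gap belongs to the place of the methyl or to the rest of the structure: in compound 4 the methyl sits on the six-membered aromatic ring with 2 nitrogen, in compound 1 on a six-membered aromatic ring of carbon only, and the two pairs also differ elsewhere, so these four compounds cannot separate the two readings.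

On these data alone, it remains open whether a methyl on the same carbon as in compound 4 costs as much with a sulfonamide in place of the methylsulfonyl, or without the fluorine. As far as these compounds go, it also remains open whether an ethyl, a chlorine or an amine on that carbon would follow the methyl, which would show whether the large step belongs to methyl alone or to any group there.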